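The compounds below may be only part of what the source reports. "The series", "measured", "known", "first", "only" and "open" are said of these compounds alone.

Measured in a functional assay on A549 cells (Homo sapiens) for inhibition, read by sulforhodamine B assay; a higher number here means a weaker inhibitor of growth, a lower number a stronger inhibitor of growth:
- compound 1 `COc1ccc(-c2ccc(-c3ccc(-c4nc5cc(C)ccc5[nH]4)cc3)cc2)cc1OC` gives 2100 nM
- compound 2 `Oc1ccc(-c2ccc(-c3ccc(-c4nc5ccccc5[nH]4)cc3)cc2)cc1` gives 33100 nM
- compound 3 `Cc1ccc2[nH]c(-c3ccc(-c4ccc(-c5ccc(F)cc5)cc4)cc3)nc2c1` gives 6030 nM

Compound 3, at 6030 nM, holds the middle of the three numbers, above compound 1 and below compound 2. Compound 4 `Cc1ccc2[nH]c(-c3ccc(-c4ccc(-c5ccc(O)cc5)cc4)cc3)nc2c1` differs from it in one place: hydroxy in place of fluoro on an aromatic carbon. Among the measured compounds shown here, one measured step touches this same place: a 2.9-fold higher number from compound 1 to compound 3 (0.46 log units; beyond the scatter). That step is modest, and it shows that a change here can move the number, but it says nothing about hydroxy itself. The nearest hint is compound 2, which carries the same 4-hydroxyphenyl on a core without the methyl and gives 33100 nM, the highest number of the three. No measurement separates the share of the hydroxy from that of the methyl. A modest rise, of about the size of the measured step, is therefore expected. The expected step is a 2.2-fold higher number from compound 3 to compound 4 (0.33 log units; beyond the scatter), towards a weaker inhibitor of growth. The estimate for compound 4 is 13000 nM, with an expected range of 4500 nM to 33000 nM.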

Compound 4, concentration for 50% growth inhibition: 3520 nM
Estimate against measurement, compound 4: 3.7-fold (0.57 log units) above; measured number outside the range, below it.
By their numbers in this assay, from the lowest: compounds 1, 4 and 3 (each within the scatter of the next, the first and the last beyond it); then compound 2.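

In this assay, hydroxy in place of fluoro on this aromatic carbon gives a 1.7-fold lower number from compound 3 to compound 4 (0.23 log units; within the scatter), so the two groups cannot be told apart at this position. The methyl on the core, not yet separable from the hydroxy, now has a step of its own, a 9.4-fold lower number from compound 2 to compound 4 (0.97 log units; beyond the scatter), which lies beyond the scatter and ties the high number of compound 2 to the missing methyl, not to the hydroxy. The 4-hydroxyphenyl and 3,4-dimethoxyphenyl groups also stay within the scatter of each other, with a 1.7-fold higher number from compound 1 to compound 4 (0.22 log units; within the scatter).

No measurement shown here explains these results. Going by these compounds, whether this position would tolerate an amine or a carboxylic acid, and whether the methyl would have the same effect with 4-fluorophenyl in place, remains open.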